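Urea series: dichlorophenyl in place of trifluoromethylphenyl

A few compounds are considered here, and "the series" means these few. Any claim that something is new, unique, unknown or untested is made for them only; others in the source may bear on it.

Three compounds of the series have numbers in a functional assay on EKVX cells (Homo sapiens) for inhibition, read by sulforhodamine B assay, with a stated time of 48 h, tested at 10 uM; a higher number here means a weaker effect of the compound at the concentration tested, a lower number a stronger effect. Compound 1 `COc1cc2cc(Oc3ccc(NC(=O)Nc4ccc(C)cc4)cc3)c(C)nc2cc1OC` gives 107% in this assay. Compound 2 `COc1cc2cc(Oc3ccc(NC(=O)Nc4ccc(C(F)(F)F)cc4)cc3)c(C)nc2cc1OC` gives 75.7% in this assay, and compound 3 `COc1cc2cc(Oc3ccc(NC(=O)Nc4cccc(C(F)(F)F)c4)cc3)c(C)nc2cc1OC` gives 15.4%. Compound 2 thus stands second highest of the three: compound 1 is nearest, with a number 31.3 percentage points lower from compound 1 to compound 2 (beyond the scatter), and compound 3 is furthest, with a number 60.3 percentage points lower from compound 2 to compound 3 (beyond the scatter). Between compound 1 and compound 3 the step was a number 91.6 percentage points lower from compound 1 to compound 3 (beyond the scatter).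

Compound 4 `COc1cc2cc(Oc3ccc(NC(=O)Nc4ccc(Cl)c(Cl)c4)cc3)c(C)nc2cc1OC` is not yet measured. It differs from compound 2 in one place: 3,4-dichlorophenyl in place of 4-(trifluoromethyl)phenyl on an amide-type nitrogen.

Within the data shown here, two measured steps bear on it. Changing the group on the phenyl attached to the amide-type nitrogen, from methyl to trifluoromethyl, gave a number 31.3 percentage points lower from compound 1 to compound 2 (beyond the scatter); moving the trifluoromethyl on that phenyl gave a number 60.3 percentage points lower from compound 2 to compound 3 (beyond the scatter). Both changes on this phenyl lowered the number beyond the scatter, so a further change of substitution on the same phenyl is expected to lower it again, although the size is uncertain because compound 3 gives 15.4% while compound 2 gives 75.7%. For compound 4 a step of a number 40.7 percentage points lower from compound 2 to compound 4 (beyond the scatter) is expected in this assay. Compound 4 is estimated at 35%, within 5% to 70%.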

Compound 4, a percentage reported as activity, at one concentration (the size of the read-out at that concentration, not a potency): 21%
For compound 4 the middle estimate is 14 percentage points above the measured one; the range from low to high includes it.
By their numbers in this assay, from the lowest: compounds 3 and 4 (each within the scatter of the next); then compound 2; then compound 1.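

In this assay, 3,4-dichlorophenyl on the amide-type nitrogen gives a large drop from 4-(trifluoromethyl)phenyl (a number 54.7 percentage points lower from compound 2 to compound 4 (beyond the scatter)) and from 4-methylphenyl (a number 86 percentage points lower from compound 1 to compound 4 (beyond the scatter)), so a low number at this position does not depend on trifluoromethyl. Against 3-(trifluoromethyl)phenyl, the same group gives no step beyond the scatter (a number 5.6 percentage points higher from compound 3 to compound 4 (within the scatter)), so these two groups cannot be told apart in this read-out. Across the four compounds, 3-(trifluoromethyl)phenyl and 3,4-dichlorophenyl carry the two low numbers while 4-methylphenyl and 4-(trifluoromethyl)phenyl carry the two higher ones, and no compound shown goes against this split. No measurement at hand accounts for these steps.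

Still open, on these data alone, is whether the split holds for other kinds of group on this phenyl, such as an amine, a carboxylic acid or a nitrile. Also open, as far as these compounds go, is whether the low numbers of compound 3 and compound 4 survive replacing the phenyl on the amide-type nitrogen with cyclohexyl or a longer alkyl chain.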